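From 4-fluorophenyl to 4-chlorophenyl: one step, one estimate

The compounds below may be only part of what the source reports. "The series", "measured", "known", "first", "only" and "open" are said of these compounds alone.

Compound 1 `O=c1[nH]c(N/N=C/c2ccccc2)nc2nc(-c3cccs3)cc(-c3ccccc3)c12`: 26800 nM
Compound 2 `O=c1[nH]c(N/N=C/c2ccc(F)cc2)nc2nc(-c3cccs3)cc(-c3ccccc3)c12`: 1540 nM

Both values come from a functional assay on PC-3 cells (Homo sapiens) for cytotoxicity, read by sulforhodamine B assay, with a stated time of 48 h; on this read-out higher numbers stand for weaker inhibition and lower numbers for stronger inhibition. Of the two compounds, compound 2 has the lower number and thus the stronger inhibition, at 1540 nM. Compound 3 `O=c1[nH]c(N/N=C/c2ccc(Cl)cc2)nc2nc(-c3cccs3)cc(-c3ccccc3)c12` has not yet been measured. It keeps the shared core and differs from compound 2 in one place: chloro in place of fluoro on an aromatic carbon, para to a large group (chloro in place of fluoro on an aromatic carbon).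

Going by the values given here, only one measured step bears on this change. Fluoro in place of hydrogen on an aromatic carbon gave a large step, a 17-fold lower number from compound 1 to compound 2 (1.24 log units; beyond the scatter). Among the compounds with values here, that step replaced hydrogen rather than fluoro, so it does not directly show what swapping fluoro for chloro will do, and no measured compound carries chloro. A repeat of that large step is therefore not expected, and the data favour no firm direction. No step beyond the scatter is expected in this assay, and the estimated change is a 1.1-fold higher number from compound 2 to compound 3 (0.04 log units; within the scatter). For compound 3, the expected value is 1700 nM, with an estimated range of 500 nM to 6000 nM.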

Compound 3, half-maximal inhibitory concentration: 23800 nM
For compound 3 the middle estimate is 14-fold (1.15 log units) below the measured one, outside the stated range (above it).
By their numbers in this assay, from the lowest: compound 2; then compounds 3 and 1 (each within the scatter of the next).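

In this assay, chloro in place of fluoro on this aromatic carbon, para to a large group, gives a 15-fold higher number from compound 2 to compound 3 (1.19 log units; beyond the scatter), so the position responds sharply to which of these two halogens it carries, and not merely to whether a halogen is present. Set against hydrogen, chloro gives a 1.1-fold lower number from compound 1 to compound 3 (0.05 log units; within the scatter), which lies within the scatter: the large step seen earlier with fluoro does not carry over to chloro, and among these three compounds only compound 2, the strongest of them, stands apart. Nothing available here accounts for why two such similar single-atom groups part so widely.

On these data alone, what remains open is whether fluoro is a lone exception at this place or one point in a broader trend, which a bromo, methoxy or amine group there could begin to show. As far as these compounds go, it is also open whether the same sharp difference between fluoro and chloro would persist if the shared core were changed elsewhere, since all three compounds keep it intact.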